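Adding a propargyl group to a carbamate-bearing core

A few compounds are considered here, and "the series" means these few. Any claim that something is new, unique, unknown or untested is made for them only; others in the source may bear on it.

Within the data shown here, the two compounds measured so far share a fused two-ring core carrying a diethylcarbamoyl group; compound 1 `CCN(CC)C(=O)Oc1ccc2[nH]ccc2c1` attaches it through an oxygen, while compound 2 `C#CCn1ccc2cc(NC(=O)N(CC)CC)ccc21` attaches it through a nitrogen and also carries a propargyl group on the ring nitrogen. In an assay on isolated protein for inhibition of Amine oxidase [flavin-containing] A (Homo sapiens), read by fluorescence, with stated times of 10 min, 10 s and 20 min (on this read-out higher numbers stand for weaker inhibition and lower numbers for stronger inhibition), compound 1 gives 13200 nM, the lower of the two numbers and thus the stronger inhibition. Compound 2 gives 33400 nM in this assay, a weaker result that lies beyond the usual scatter. Compound 2 differs from compound 1 in two places at once, so its number cannot be traced to either change alone.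

Compound 3 `C#CCn1ccc2cc(OC(=O)N(CC)CC)ccc21` has not been measured yet. It is derived from compound 1 by a single change: propargyl in place of hydrogen on an aromatic nitrogen. Among the measured compounds shown here, no step of this kind has been measured among the compounds, so the direction is uncertain; the change is expected to leave the inhibition roughly where compound 1 stands or to improve it modestly, with the step of a 1.5-fold lower number from compound 1 to compound 3 (0.17 log units; within the scatter) as the expected outcome. Compound 3 is accordingly estimated at 9000 nM, within a range of 2500 nM to 30000 nM.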

Compound 3, half-maximal inhibitory concentration: 99100 nM
The estimate for compound 3 lay 11-fold (1.04 log units) below the measured number, and the stated range ends below it.
By their numbers in this assay, from the lowest: compound 1; then compound 2; then compound 3.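

This step isolates the aromatic nitrogen of the shared core: in this assay, propargyl in place of hydrogen gives a 7.5-fold higher number from compound 1 to compound 3 (0.88 log units; beyond the scatter), so on the core of compound 1 this position does not accept the change without a loss of inhibition. The two propargyl compounds also do not give the same number, since compound 2 gives 33400 nM and compound 3 gives 99100 nM, so the result at this nitrogen cannot be read apart from how the diethylcarbamoyl group is attached. Nothing measured here explains why the number rose.

From the compounds shown here alone, it remains open whether the loss comes with any group on this nitrogen or is specific to propargyl, which a methyl group or a plain propyl chain in the same place would help to settle, as would a longer chain ending in an amine. Going by these compounds, it is also open whether a compound with hydrogen on this nitrogen and the diethylcarbamoyl group attached through a nitrogen would stand closer to compound 1 or to compound 2.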